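A Change of Aryl Group at a Short Half-Life

The source may hold more compounds than are shown below. What is called first, only, known or untested is meant among the compounds shown, and "the series" means these compounds.

In an ADME assay on microsomes from liver (Rattus norvegicus) for metabolic stability, read by LC-MS, using NADPH, at 37 degrees C (a lower number here means that the compound disappears faster, a higher number that the compound lasts longer), compound 1 `Cc1oc(-c2c(Br)cccc2Br)nc1CN1CCC(C(=O)NCCCN2C[C@H](C)C[C@H](C)C2)CC1` gives 0.035 h and compound 2 `Cc1cccc(F)c1-c1nc(CN2CCC(C(=O)NCCCN3C[C@H](C)C[C@H](C)C3)CC2)c(C)o1` gives 0.0733 h, the higher of the two numbers. Compound 3 `CCc1ccccc1-c1nc(CN2CCC(C(=O)NCCCN3C[C@H](C)C[C@H](C)C3)CC2)c(C)o1` carries 2-ethylphenyl in place of 2-fluoro-6-methylphenyl on an aromatic carbon. Going by the values given here, one measured step touches the same place, a 2.1-fold higher number from compound 1 to compound 2 (0.32 log units; beyond the scatter), which is modest and only just beyond the scatter. It involves a different exchange, so it fixes no direction, and no change beyond the scatter is expected. The expected step is a 1.3-fold lower number from compound 2 to compound 3 (0.12 log units; within the scatter). For compound 3 the estimated value is 0.055 h, within a range of 0.025 h to 0.12 h.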

Compound 3, half-life: 0.283 h
The estimate for compound 3 lay 5.1-fold (0.71 log units) below the measured number; the measured number lies above the stated range.
By their numbers in this assay, from the lowest: compound 1; then compound 2; then compound 3.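

In this assay, putting 2-ethylphenyl in place of 2-fluoro-6-methylphenyl gives a 3.9-fold higher number from compound 2 to compound 3 (0.59 log units; beyond the scatter), and putting it in place of 2,6-dibromophenyl gives an 8.1-fold higher number from compound 1 to compound 3 (0.91 log units; beyond the scatter). The position therefore responds beyond the scatter even when the count of 8 heavy atoms stays the same, and among these three compounds the aryl group without halogen gives the highest number. Nothing available accounts for this step. As far as these compounds go, what 2-propylphenyl or 2-methoxyphenyl would give at this place remains open. Also open, from the compounds shown here alone, is whether the ethyl group or the loss of fluorine carries the step, since the two changes come together here.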